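Removing One Methoxy Group: An Expected Cytotoxicity Reading

The source may hold more compounds than are shown below. What is called first, only, known or untested is meant among the compounds shown, and "the series" means these compounds.

Compound 1, `COc1ccc(-c2cc(/C=C/C(=O)c3ccc(N)cc3)[nH]n2)cc1`: 103%
Compound 2, `COc1cc(-c2cc(/C=C/C(=O)c3ccc(N)cc3)[nH]n2)cc(OC)c1OC`: 90%
Compound 3, `COc1ccc(C(=O)/C=C/c2cc(-c3cc(OC)c(OC)c(OC)c3)n[nH]2)cc1`: 89%

In a functional assay on MDA-MB-468 cells (Homo sapiens) for cytotoxicity, read by sulforhodamine B assay, with a stated time of 48 h, tested at 0.01 uM (on this read-out higher numbers stand for a weaker effect at the one concentration tested and lower numbers for a stronger effect), compound 2 stands second highest of the three numbers; compound 3 lies within the scatter of it, while compound 1 lies beyond the scatter above it. Compound 4, `COc1ccc(-c2cc(/C=C/C(=O)c3ccc(N)cc3)[nH]n2)cc1OC`, differs from compound 2 by hydrogen in place of methoxy on an aromatic carbon. Within the data shown here, the only measured single-place step, a number 1 percentage points lower from compound 2 to compound 3 (within the scatter), concerns a different group on a different ring and offers no guide to removing a methoxy. Compound 1, which carries fewer methoxy groups on that ring, gives 103%, whereas compound 2 gives 90%. Compound 4 sits between these two structures, so a small rise, a number 6 percentage points higher from compound 2 to compound 4 (within the scatter), is expected. Compound 4 is therefore estimated at 96%, with a range from 86% to 106%.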

Compound 4, a percentage reported as activity, at one concentration (the size of the read-out at that concentration, not a potency): 94%
Compound 4: middle estimate off by 2 percentage points, on the high side; the measured number falls inside the stated range.
By their numbers in this assay, from the lowest: compounds 3, 2, 4 and 1 (each within the scatter of the next, the first and the last beyond it).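

In this assay, among these compounds, hydrogen in place of methoxy on an aromatic carbon gives a number 4 percentage points higher from compound 2 to compound 4 (within the scatter), which is the first reading of this change on this ring. The opposite change, methoxy in place of hydrogen, gives a number 9 percentage points lower from compound 1 to compound 4 (within the scatter), so neither single step on this ring moves the reading past the usual scatter. No measured finding is available to explain these readings. The compounds shown leave open whether a chlorine atom or an ethoxy group at this position would read differently from methoxy or hydrogen.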